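The source may report more compounds than this note shows. Statements on the series, on what has been measured and on what is new or still open speak of the compounds shown alone.

Measured compounds:
compound 1 `COc1cc(C)cc(-c2c(-c3ccnc(-c4ccc(C(C)=O)cc4)c3)cnn2CC#N)c1`, 6960 nM in a functional assay on NCI-H522 cells (Homo sapiens) for inhibition, read by sulforhodamine B assay, with a stated time of 48 h; on this read-out higher numbers stand for weaker inhibition of growth and lower numbers for stronger inhibition of growth
compound 2 `Cc1cc(O)cc(-c2nn(CC#N)cc2-c2ccnc(-c3ccc(Oc4ccccc4)cc3)c2)c1`, 10400 nM in this assay

Compound 2 and compound 1 give numbers that lie within the scatter of each other in this assay, so neither can be ranked against the other. Compound 3 `Cc1cc(O)cc(-c2nn(CC#N)cc2-c2ccnc(-c3ccc(N(C)C)cc3)c2)c1` carries dimethylamino in place of phenoxy on an aromatic carbon relative to compound 2. For the measured compounds named here, no step of this kind is available among the measured pair, and nothing among them suggests a move beyond the scatter. Compound 3 is therefore expected to come out close to compound 2, as a 1.2-fold lower number from compound 2 to compound 3 (0.09 log units; within the scatter). The estimate for compound 3 is 8500 nM, with a range of 3000 nM to 25000 nM.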

Compound 3, concentration for total growth inhibition: 7140 nM
The estimate for compound 3 lay 1.2-fold (0.08 log units) above the measured number, and the stated range covers the measured number.
By their numbers in this assay, from the lowest: compounds 1, 3 and 2 (each within the scatter of the next).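

Dimethylamino in place of phenoxy on an aromatic carbon, para to a large group, gives a 1.5-fold lower number from compound 2 to compound 3 (0.16 log units; within the scatter) in this assay. This first single-place step shows that, on this core, a group of 7 heavy atoms with one six-membered aromatic ring and a group of 3 heavy atoms with no ring give numbers within the scatter of each other. No other data bear on this result.

From the compounds shown here alone, it remains open whether a carboxylic acid or a primary amine at this position would give a step beyond the scatter.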